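One Side-Chain Swap, Tried on a Second Core

The source may report more compounds than this note shows. Statements on the series, on what has been measured and on what is new or still open speak of the compounds shown alone.

Three compounds have been measured in a functional assay on MGC-803 cells (Homo sapiens) for inhibition, read by MTT assay, with a stated time of 48 h; a higher number here means a weaker inhibitor, a lower number a stronger inhibitor:

compound 1, `Cc1ccc(NC(=S)NC(=O)c2ccc(OCc3ccccc3F)cc2)cc1-c1nc2ccccc2[nH]1`, gives 3070 nM
compound 2, `Cc1ccc(NC(=S)NC(=O)c2ccc(OCc3cccc(Cl)c3Cl)cc2)cc1-c1nc2ccccc2[nH]1`, gives > 100000 nM, which is a limit of the assay and not a number
compound 3, `Cc1ccc(NC(=O)NC(=O)c2ccc(OCc3ccccc3F)cc2)cc1-c1nc2ccccc2[nH]1`, gives 2520 nM

Compound 1 and compound 2 differ in one place, (2,3-dichlorophenyl in place of 2-fluorophenyl on a saturated chain carbon bound to an oxygen on an aromatic ring). That change brought an at least 32-fold higher number from compound 1 to compound 2 (1.51 log units; beyond the scatter), so the inhibition fell away to the edge of what this assay can report.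

Compound 3 is built on a different core; how the core of compound 3 differs from the core of compound 1 is not broken down here. In this assay compound 3 and compound 1 sit close together, and their gap is within the usual scatter.

Compound 4, `Cc1ccc(NC(=O)NC(=O)c2ccc(OCc3cccc(Cl)c3Cl)cc2)cc1-c1nc2ccccc2[nH]1`, has not yet been measured. It relates to compound 3 exactly as compound 2 relates to compound 1: 2,3-dichlorophenyl in place of 2-fluorophenyl on a saturated chain carbon bound to an oxygen on an aromatic ring. The place of the change is the same in both pairs. Among the measured compounds shown here, the only measured example of this change is the large loss from compound 1 to compound 2, and compound 3 starts from about where compound 1 starts, so a loss of similar size is expected from compound 3 to compound 4, a 32-fold higher number from compound 3 to compound 4 (1.50 log units; beyond the scatter), with the result most likely again at the edge of the assay. Because compound 2 reached (the limit of > 100000 nM in this assay, at which 1 of the 3 values shown sits), compound 4 is expected to give about 80000 nM, between 20000 nM and 300000 nM, and quite possibly only a limit.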

Compound 4, half-maximal inhibitory concentration: > 100000 nM
Compound 4 was reported as a limit; the forecaster's own chance of this, stated with the estimate: 65%; at least 1.2-fold (0.09 log units) between middle value and limit.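

In this assay, putting 2,3-dichlorophenyl in place of 2-fluorophenyl brings a large loss on the second core, just as it did on the first, with an at least 39-fold higher number from compound 3 to compound 4 (1.59 log units; beyond the scatter). From the compounds shown here alone, compound 4 gives > 100000 nM, which is a limit of the assay and not a number, so the change carries over in its direction and in being large, while its true size on this core stays unknown. These two pairs show that the loss appears on both of these cores, but they say nothing about any further core, and they cannot show that the loss is equally large on both: the same change on two cores in this assay, an at least 32-fold higher number (1.51 log units; beyond the scatter) from compound 1 to compound 2 and an at least 39-fold higher number (1.59 log units; beyond the scatter) from compound 3 to compound 4; the limit leaves it open whether they differ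

The compounds shown leave open which part of the change matters, since the fluorine goes and two chlorines arrive in a single step, and a plain phenyl or a phenyl with a single chlorine would help to separate these effects. Going by these compounds, it also remains open whether another group on this benzyl ring, such as a methoxy group, would keep the inhibition seen with 2-fluorophenyl on both cores.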